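Cytotoxicity in HEL Cells for Four Related Compounds

This account rests on a few compounds, and the source may have more. Where it says the series, first, only, none or still open, it means among the compounds named here.

Compound 1 `CCCCCCCCCCC#Cc1cc2cn(C)c(=O)nc2o1` gives in a functional assay on HEL cells (Homo sapiens) for cytotoxicity (a higher number here means that more compound is tolerated, a lower number that less compound is tolerated), only a limit of the assay, > 150000 nM.
Compound 2 `CCCCCCCCCCC#Cc1cc2cn([C@@H]3O[C@H](CO)[C@@H](O)[C@@H]3O)c(=O)nc2o1` gives in this assay a value of 116000 nM.
Compound 3 `CCCCCCCCC#Cc1cc2cn(C)c(=O)nc2o1` gives in this assay only a limit of the assay, > 175000 nM.

The change from compound 1 to compound 2 is 3,4-dihydroxy-5-(hydroxymethyl)oxolan-2-yl in place of methyl on an aromatic nitrogen. It made the step of an at least 1.2-fold lower number from compound 1 to compound 2 (0.11 log units; that floor lies within the scatter), which rests on the limit (the limit of > 150000 nM in this assay, at which 1 of the 3 values shown sits). The cores of compound 1 and compound 3 differ as hydrogen in place of ethyl on a saturated chain carbon, eight bonds along the chain from a triple-bonded carbon, and the step that the two limits leave unreadable from compound 1 to compound 3 is bounded by the limit of > 150000 nM in this assay, at which 1 of the 3 values shown sits, and (the limit of > 175000 nM in this assay, at which 1 of the 3 values shown sits).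

Compound 4 `CCCCCCCCC#Cc1cc2cn([C@@H]3O[C@H](CO)[C@@H](O)[C@@H]3O)c(=O)nc2o1` is not yet measured. It carries the same change as compound 2, (3,4-dihydroxy-5-(hydroxymethyl)oxolan-2-yl in place of methyl on an aromatic nitrogen), placed word for word the same. The step from compound 3 to compound 4 is expected to be an at least 1.2-fold lower number from compound 3 to compound 4 (0.09 log units; that floor lies within the scatter), resting on an at least 1.2-fold lower number from compound 1 to compound 2 (0.11 log units; that floor lies within the scatter) and on the limit (the limit of > 175000 nM in this assay, at which 1 of the 3 values shown sits). Compound 4 is therefore estimated at 140000 nM, between 70000 nM and 300000 nM.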

Compound 4, half-maximal cytotoxic concentration: > 124000 nM
Compound 4 gave a limit, no number; the forecaster's own chance of this, stated with the estimate: 40%; the middle value is on the limit's open side.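

In this assay compound 4 gives only a limit of the assay, > 124000 nM. Compound 3 and compound 4 both stand at limits, so neither the step that carries 3,4-dihydroxy-5-(hydroxymethyl)oxolan-2-yl in place of methyl onto the core of compound 3 nor the step between compound 1 and compound 3 can be read, and whether the change acts alike on both cores is not shown. The one readable step, an at least 1.0-fold higher number from compound 2 to compound 4 (0.02 log units; that floor lies within the scatter), links the two compounds carrying this group, and it shows no difference beyond the scatter and rests on a limit: the limit of > 124000 nM in this assay, at which 1 of the 4 values shown sits.

The compounds shown leave open how an amine or a carboxylic acid on the aromatic nitrogen would stand in this assay. They also leave open whether a longer chain would give a number rather than a limit.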